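This account rests on a few compounds, and the source may have more. Where it says the series, first, only, none or still open, it means among the compounds named here.

Of the compounds shown here, two from this series have been measured. Compound 1 `CCCS(=O)(=O)Nc1ccc(F)c(C(=O)c2n[nH]c3ncc(-c4ccc(N)cc4)cc23)c1F` gives 0.1% in an assay for binding affinity to dual specificity mitogen-activated protein kinase kinase 4 (Homo sapiens), read by KINOMEscan, tested at 100 nM (on this read-out lower numbers stand for a stronger effect and higher numbers for a weaker effect at the one concentration tested), and compound 2 `CCCS(=O)(=O)Nc1ccc(F)c(C(=O)c2n[nH]c3ncc(-c4ccc(N(C)C)cc4)cc23)c1F` gives 2.5% in the same assay. Within the data shown here, compound 2 stands alongside compound 1: the only step so far, a number 2.4 percentage points higher from compound 1 to compound 2 (within the scatter), lies within the usual scatter, so the two compounds cannot be told apart on this read-out.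

Compound 3 `CCCS(=O)(=O)Nc1ccc(F)c(C(=O)c2n[nH]c3ncc(-c4ccc(C)c(C)c4)cc23)c1F` has not yet been measured. It differs from compound 2 in one place: 3,4-dimethylphenyl in place of 4-(dimethylamino)phenyl on an aromatic carbon. Among the measured compounds shown here, no measured step bears directly on this change; the step from compound 1 to compound 2 concerns only the amino-bearing group and was within the scatter. Because both compound 1 at 0.1% and compound 2 at 2.5% give very low numbers, compound 3 is expected to stay low as well, with a step of about a number 0.5 percentage points higher from compound 2 to compound 3 (within the scatter) that is expected to stay within the scatter. The estimated value for compound 3 is 3%, within a range from 0% to 15%.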

Compound 3, a percentage reported as activity, at one concentration (the size of the read-out at that concentration, not a potency): 20%
Compound 3: the middle estimate sits 17 percentage points below what was measured; the measured number lies above the stated range.
By their numbers in this assay, from the lowest: compounds 1 and 2 (each within the scatter of the next); then compound 3.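

In this assay, this position on the ring now shows a step larger than the scatter: 3,4-dimethylphenyl in place of 4-(dimethylamino)phenyl gives a number 17.5 percentage points higher from compound 2 to compound 3 (beyond the scatter), and the same group in place of 4-aminophenyl gives a number 19.9 percentage points higher from compound 1 to compound 3 (beyond the scatter). The two phenyl groups that carry a nitrogen could not be told apart, whereas the group with only carbon substituents stands apart from both, which shows that the read-out does respond to what this phenyl ring carries. Nothing available explains this difference.

The swap removes the nitrogen and changes the ring's substitution in a single move, leaving open which of the two matters. A 4-methylphenyl would separate these two changes, and a 4-methoxyphenyl would show how an oxygen in that place compares.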